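The compounds below may be only part of what the source reports. "The series", "measured", "known", "first", "only" and "open" are said of these compounds alone.

Measured so far in an ADME assay for permeability, using PAMPA, with a stated time of 3 h; on this read-out higher numbers stand for higher permeability and lower numbers for lower permeability:
Compound 1 `O=C(Nc1ccc([N+](=O)[O-])c(Cl)c1)c1cc(Cl)ccc1O`: 12.3 10^-6 cm/s
Compound 2 `O=C(Nc1cccc(Cl)c1)c1cc(Cl)ccc1O`: 8.6 10^-6 cm/s

Only these two compounds have numbers in this assay, and they lie within the scatter of each other, so compound 2 stands level with the only reference available. The next compound to be measured is compound 3 `O=C(Nc1ccc(F)c(Cl)c1)c1cc(Cl)ccc1O`, which keeps the core of compound 2 and adds one substituent. The change is fluoro in place of hydrogen on an aromatic carbon, ortho to a chloro group and para to a large group.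

Among the measured compounds shown here, one measured step bears on this change, and it involves the same carbon: hydrogen in place of nitro gave a 1.4-fold lower number from compound 1 to compound 2 (0.16 log units; within the scatter). Exchanging a much larger group there did not move the read-out beyond the scatter. For the measured compounds named here, a single step is thin evidence, and no measured compound carries fluoro, but no step beyond the scatter is expected for this smaller exchange. The expected change is a 1.1-fold higher number from compound 2 to compound 3 (0.04 log units; within the scatter). For compound 3 the estimated value is 9.5 10^-6 cm/s, with an expected range from 5 10^-6 cm/s to 18 10^-6 cm/s.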

Compound 3, apparent permeability: 11.5 10^-6 cm/s
For compound 3 the middle estimate is 1.2-fold (0.08 log units) below the measured one, and the stated range covers the measured number.
By their numbers in this assay, from the lowest: compounds 2, 3 and 1 (each within the scatter of the next).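

In this assay the carbon ortho to a chloro group and para to a large group now has three occupants on the same core, so fluoro can be read against both hydrogen and nitro. Fluoro in place of hydrogen gives a step within the scatter (a 1.3-fold higher number from compound 2 to compound 3 (0.13 log units; within the scatter)), and fluoro in place of nitro does too (a 1.1-fold lower number from compound 1 to compound 3 (0.03 log units; within the scatter)), which means that hydrogen, fluoro and nitro cannot be put in any order at this carbon, and the earlier single step now has two further steps beside it that agree with it in staying within the scatter. Nothing in the material shown explains why these three compounds stay so close, and no independent measurement bears on this result.

Whether this tolerance extends to other kinds of group stays open, since the compounds shown say nothing about an amine, a carboxylic acid or a longer chain on this carbon. All three compounds also keep the neighbouring chloro group and the rest of the shared core unchanged, so what a change in those places would do to the read-out cannot be told from them.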